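A few compounds are considered here, and "the series" means these few. Any claim that something is new, unique, unknown or untested is made for them only; others in the source may bear on it.

Compound 1 `Oc1nc2nonc2nc1Nc1ccc(OC(F)(F)F)cc1Cl`: 1400 nM
Compound 2 `Oc1nc2nonc2nc1Nc1ccc(OCc2ccccc2)cc1`: 2400 nM
Compound 3 `Oc1nc2nonc2nc1Nc1ccccc1`: 66700 nM

These three compounds share the same core and differ only in the groups on the attached phenyl ring. In an assay on mitochondria from L6 cells (Rattus norvegicus) for activation, with a stated time of 90 min (a lower number here means that less compound is needed, a higher number that more compound is needed for the effect), compound 1 gives 1400 nM, compound 2 gives 2400 nM, and compound 3 gives 66700 nM. Compound 3, which carries no substituent on that ring, stands highest of the three numbers. Going by the values given here, the single measured step that leads to it, a 28-fold higher number from compound 2 to compound 3 (1.44 log units; beyond the scatter), is large and well beyond the scatter, showing that a substituent on this ring matters a great deal.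

Compound 4 `Oc1nc2nonc2nc1Nc1ccccc1Cl` differs from compound 3 by chloro in place of hydrogen on an aromatic carbon, sitting on an aromatic carbon of a six-membered aromatic ring of carbon only. Among the compounds with values here, no measured step concerns a chloro on its own; the only step measured involves a benzyloxy, so it bears on compound 4 only indirectly. Compound 1 carries a chloro together with a trifluoromethoxy, and its number is far lower than that of compound 3, yet the share of the chloro in that cannot be separated from these values. A modest downward step is therefore expected, a 3.3-fold lower number from compound 3 to compound 4 (0.52 log units; beyond the scatter), with the chance that it stays within the scatter. Compound 4 is estimated to give 20000 nM, within a range from 5000 nM to 70000 nM.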

Compound 4, half-maximal effective concentration: 6300 nM
Estimate against measurement, compound 4: 3.2-fold (0.50 log units) above; the measured number falls inside the stated range.
By their numbers in this assay, from the lowest: compounds 1 and 2 (each within the scatter of the next); then compound 4; then compound 3.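

In this assay, a single chlorine atom, ortho to a large group on the six-membered aromatic ring, is enough for a large change, an 11-fold lower number from compound 3 to compound 4 (1.02 log units; beyond the scatter), whereas the earlier measured step on this ring involved only the far larger benzyloxy. With that chloro already in place, taking away the trifluoromethoxy gives a 4.5-fold higher number from compound 1 to compound 4 (0.65 log units; beyond the scatter), a modest step that is still beyond the scatter, so the chloro alone accounts for a large part of what the ring substituents of compound 1 provide in this series. No measurement is available that explains why either change alters the number.

From the compounds shown here alone, whether a fluoro, a bromo, a methyl or a methoxy on the same ring carbon would produce a step of similar size remains open, as does the effect of an amine or a carboxylic acid there. Also open, going by these compounds, is whether adding the chloro to compound 2, with its benzyloxy group, would lower the number further or change little.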